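Swapping Pyridinyl for Furoyl on the Piperazine Nitrogen

This account rests on a few compounds, and the source may have more. Where it says the series, first, only, none or still open, it means among the compounds named here.

Compound 3 `N#C/N=C(\NCCCN1CCN(c2ccccn2)CC1)c1ccccn1` gives 130 nM in an assay for displacement of a labelled ligand from Adrenergic receptor alpha-1 (Rattus norvegicus), read by scintillation counting, with a stated time of 30 min; a higher number here means a weaker inhibitor, a lower number a stronger inhibitor. Of the two numbers shown it is the highest, but its nearest neighbour, compound 1 `COc1ccccc1N1CCN(CCCN/C(=N\C#N)c2ccccn2)CC1`, gives 105 nM, and the step of a 1.2-fold higher number from compound 1 to compound 3 (0.09 log units; within the scatter) stays within the scatter. Compound 2 `COc1ccc(N2CCN(CCCN/C(=N\C#N)c3ccccn3)CC2)cc1` gives > 10000 nM in this assay, which is a limit and not a number (the limit of > 10000 nM in this assay, at which 1 of the 3 values shown sits). The steps of an at least 95-fold higher number from compound 1 to compound 2 (1.97 log units; beyond the scatter) and an at least 76-fold lower number from compound 2 to compound 3 (1.88 log units; beyond the scatter) show that the group on an amine nitrogen in a ring of the shared core can shift the number far in either direction. Compound 4 `N#C/N=C(\NCCCN1CCN(C(=O)c2ccco2)CC1)c1ccccn1` alters that same place: (furan-2-yl)carbonyl in place of pyridin-2-yl on an amine nitrogen in a ring. Going by the values given here, no measured step covers a carbonyl-linked group there, so the expectation leans on the size of the two large steps alone, and a step beyond the scatter towards a weaker number is expected, a 23-fold higher number from compound 3 to compound 4 (1.36 log units; beyond the scatter). Compound 4 is estimated at 3000 nM, with a range from 400 nM to 20000 nM.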

Compound 4, inhibition constant: "not active" (no number reported)
The entry for compound 4 holds no number, so the estimate cannot be set against anything.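

In this assay, going by these compounds alone, compound 4 is recorded as "not active" with no number, so no step from compound 3 to compound 4 can be read. The compounds shown leave open whether compound 4 would stand near the one limit recorded, that of compound 2: the limit of > 10000 nM in this assay, at which 1 of the 4 values shown sits.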